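A few compounds are considered here, and "the series" means these few. Any claim that something is new, unique, unknown or untested is made for them only; others in the source may bear on it.

Compound 1 `NC1=NC2(CCSCC2)N(OCCCOc2cccc(Cl)c2Cl)C(N)=N1` gives 1 nM in a functional assay on A549 cells (Homo sapiens) for antiproliferative activity, read by MTT assay, with a stated time of 72 h (on this read-out higher numbers stand for weaker inhibition and lower numbers for stronger inhibition), the lowest of the three numbers recorded. Going by the values given here, compound 2 `NC1=NC2(CCOCC2)N(OCCCOc2ccc(Cl)cc2Cl)C(N)=N1` gives 70 nM and compound 3 `NC1=NC2(CCOCC2)N(OCCCOc2cccc(Br)c2)C(N)=N1` gives 160 nM; the only single-place step among the measured compounds, a 2.3-fold higher number from compound 2 to compound 3 (0.36 log units; beyond the scatter), is modest. Compound 4 `NC1=NC2(CCSCC2)N(OCCCOc2ccccc2Br)C(N)=N1` differs from compound 1 by 2-bromophenyl in place of 2,3-dichlorophenyl on an oxygen on a saturated carbon. The step from compound 2 to compound 3 likewise swaps a dichlorophenyl for a bromophenyl on the oxygen on a saturated carbon, so a comparable, modest weakening is the most that the data suggest, with the reading for compound 4 expected to stay near that of compound 1. Compound 4 is therefore estimated at 3 nM, between 1 nM and 10 nM, a step of a 3.0-fold higher number from compound 1 to compound 4 (0.48 log units; beyond the scatter).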

Compound 4, half-maximal inhibitory concentration: 40 nM
Compound 4: middle estimate off by 13-fold (1.12 log units), on the low side; the whole stated range lies below it.
By their numbers in this assay, from the lowest: compound 1; then compounds 4 and 2 (each within the scatter of the next); then compound 3.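

In this assay the change from 2,3-dichlorophenyl to 2-bromophenyl on an oxygen on a saturated carbon proves large (a 40-fold higher number from compound 1 to compound 4 (1.60 log units; beyond the scatter)), well beyond the modest step seen earlier for another swap of a dichlorophenyl for a bromophenyl (a 2.3-fold higher number from compound 2 to compound 3 (0.36 log units; beyond the scatter)). The number at this position thus depends strongly on which halogenated phenyl is present, and one such swap does not predict the size of another. No evidence at hand explains the size of this step. From the compounds shown here alone, whether 2-chlorophenyl would hold the low number of compound 1 stays open, as does how an aminophenyl or a longer chain on the oxygen would read.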